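The source may hold more compounds than are shown below. What is called first, only, known or untested is meant among the compounds shown, and "the series" means these compounds.

Working notes on the series. Compound 1 `C=C(F)C(=O)Nc1cc(Nc2nccc(-c3cn(C)c4ccccc34)n2)c(OC)cc1N(C)CCN(C)C`, compound 2 `COc1cc(N(C)CCN(C)C)c(NC(=O)C(Cl)=C(Cl)Cl)cc1Nc1nccc(-c2cn(C)c3ccccc23)n1` and compound 3 `C/C=C\C(=O)Nc1cc(Nc2nccc(-c3cn(C)c4ccccc34)n2)c(OC)cc1N(C)CCN(C)C` share one core and differ only in the acyl group on the amide. In a functional assay on NCI-H1975 cells (Homo sapiens) for antiproliferative activity, read by MTT assay, with a stated time of 72 h (on this read-out higher numbers stand for weaker inhibition and lower numbers for stronger inhibition), compound 1 gives 4230 nM. Compound 2 gives only a limit of the assay, > 50000 nM, in this assay (the limit of > 50000 nM in this assay, at which 1 of the 3 values shown sits). Compound 3 gives 4540 nM in this assay, the highest of the two numbers available, with compound 1 nearest to it. The steps read a 1.1-fold higher number from compound 1 to compound 3 (0.03 log units; within the scatter), an at least 11-fold higher number from compound 1 to compound 2 (1.07 log units; beyond the scatter) and an at least 11-fold lower number from compound 2 to compound 3 (1.04 log units; beyond the scatter).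

Compound 4 `COc1cc(N(C)CCN(C)C)c(NC(=O)C=C(C)C)cc1Nc1nccc(-c2cn(C)c3ccccc23)n1` is the next member: 2-methylprop-1-en-1-yl in place of prop-1-en-1-yl on a carbonyl carbon. The step from compound 1 to compound 3 is the one most like it, an exchange of one small acyl group for another, and it stayed within the scatter. The two large steps involving compound 2 both concern the trichloroethenyl group and are not of this kind. An expectation of a small to moderate increase in number is therefore drawn for the step from compound 3 to compound 4, a 2.0-fold higher number from compound 3 to compound 4 (0.30 log units; within the scatter), far short of what compound 2 showed. Compound 4 is accordingly estimated at 9000 nM in this assay, within a range of 3000 nM to 30000 nM.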

Compound 4, half-maximal inhibitory concentration: 5610 nM
For compound 4 the middle estimate is 1.6-fold (0.21 log units) above the measured one, and the stated range covers the measured number.
By their numbers in this assay, from the lowest: compounds 1, 3 and 4 (each within the scatter of the next). At a limit, above all of these: compound 2.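

Putting 2-methylprop-1-en-1-yl in place of prop-1-en-1-yl on the carbonyl carbon gives a 1.2-fold higher number from compound 3 to compound 4 (0.09 log units; within the scatter) in this assay and, against the 1-fluoroethenyl group, a 1.3-fold higher number from compound 1 to compound 4 (0.12 log units; within the scatter) on the same read-out. The 1-fluoroethenyl, prop-1-en-1-yl and 2-methylprop-1-en-1-yl amides therefore form a group of three with no order among them, and the extra carbon of the 2-methylprop-1-en-1-yl group moves the number by no more than the scatter. The step of an at least 8.9-fold lower number from compound 2 to compound 4 (0.95 log units; beyond the scatter) lies beyond the scatter and extends the separation of the trichloroethenyl amide to a third acyl group, although compound 2 itself gives only a limit of the assay: the limit of > 50000 nM in this assay, at which 1 of the 4 values shown sits.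

The compounds shown leave open whether this flat level persists with other groups on the carbonyl carbon, such as an unsubstituted ethenyl, an ethenyl carrying a dimethylamino-bearing chain, or a longer alkyl chain. They also leave open how much of the gap to compound 2 belongs to the number of chlorine atoms, which a monochloroethenyl or dichloroethenyl amide would help to separate.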